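Trimming the ring nitrogen of compound 3

A few compounds are considered here, and "the series" means these few. Any claim that something is new, unique, unknown or untested is made for them only; others in the source may bear on it.

Measured in an in vitro ADME assay on microsomes (Homo sapiens) for metabolic stability; a higher number here means that the compound lasts longer, a lower number that the compound disappears faster:
- Compound 1 `Cn1cnc(C(=O)N(Cc2cccc(OC(F)(F)F)c2)C[C@H]2[C@@H]3CN(CC4CC4)C[C@@H]32)c1`: 0.202 h
- Compound 2 `CCN1C[C@@H]2[C@H](C1)[C@H]2CN(Cc1cccc(Cl)c1)C(=O)c1cn(C)cn1`: 1.05 h
- Compound 3 `CN1C[C@@H]2[C@H](C1)[C@H]2CN(Cc1cccc(Cl)c1)C(=O)c1cn(C)cn1`: > 2 h (a limit)

Compound 3 gives > 2 h, which is a limit of the assay and not a number. It is the only one of the three in this position: the limit of > 2 h in this assay, at which 1 of the 3 values shown sits. Compound 4 `Cn1cnc(C(=O)N(Cc2cccc(Cl)c2)C[C@H]2[C@@H]3CNC[C@@H]32)c1` carries one change: hydrogen in place of methyl on an amine nitrogen in a ring. The closest measured step puts hydrogen in place of methyl on a saturated chain carbon bound to an amine nitrogen in a ring, an at least 1.9-fold higher number from compound 2 to compound 3 (0.27 log units; that floor lies within the scatter). That floor lies within the scatter, so it offers only a faint hint of longer survival, and no change beyond the scatter is expected in this assay. The expected step is a step that the limit leaves unreadable from compound 3 to compound 4. For compound 4 the estimate is 2.5 h, with an expected range from 1 h to 6 h.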

Compound 4, half-life: > 2 h
Compound 4 ended at the assay's limit; the forecaster's own chance of this, stated with the estimate: 55%; the middle value lies beyond the limit too.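

In this assay compound 4 gives > 2 h, which is a limit of the assay and not a number. Among these compounds, with hydrogen in place of ethyl on the amine nitrogen in a ring, the one readable step is an at least 1.9-fold higher number from compound 2 to compound 4 (0.27 log units; that floor lies within the scatter). The step that removes the methyl cannot be read, so the ring nitrogen with only hydrogen on it and the methylated one cannot be ranked: the limit of > 2 h in this assay, at which 2 of the 4 values shown sit.

Going by these compounds, how long either compound really lasts remains open. So does the outcome in this assay with a propyl chain or an acetyl group on this ring nitrogen.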